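Removing the benzyl ester: from compound 3 to compound 4

A few compounds are considered here, and "the series" means these few. Any claim that something is new, unique, unknown or untested is made for them only; others in the source may bear on it.

Measured so far:
compound 1, `CC[C@H](C)[C@H](NC(=O)CN(c1nc(Cl)nc2[nH]cnc12)C1CC1)C(=O)O`: 30.3%
compound 2, `O=C(CN(c1nc(Cl)nc2[nH]cnc12)C1CC1)N[C@@H](CO)C(=O)O`: 38.7%
compound 3, `CSCC[C@H](NC(=O)CN(c1nc(Cl)nc2[nH]cnc12)C1CC1)C(=O)OCc1ccccc1`: 22.2%

All three compounds share one core and were tested in a functional assay on the whole organism (Tail, strain ICR) with Mus musculus as the target, in the tail flick test, with a stated time of 30 min, at a dose of 25 umol/kg by the oral route; a lower number here means a weaker effect, a higher number a stronger effect of the compound at the dose given. Among the measured compounds shown here, compound 1 gives 30.3% and compound 2 gives 38.7%; the one measured step, a number 8.4 percentage points higher from compound 1 to compound 2 (within the scatter), lies within the usual scatter. Compound 3 gives 22.2%, the lowest of the three numbers: its gap to compound 1 is within the scatter, its gap to compound 2 beyond it.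

Compound 4, `CSCC[C@H](NC(=O)CN(c1nc(Cl)nc2[nH]cnc12)C1CC1)C(=O)O`, has not yet been measured. It differs from compound 3 in one place: hydrogen in place of benzyl on an oxygen next to a carbonyl group. Put another way, benzyloxycarbonyl becomes carboxy.

For the measured compounds named here, no measured step shows this exact change. Going by the values given here, the only step on record, from compound 1 to compound 2, alters a different part of the molecule and was within the scatter. What the data do offer is that compound 1, which carries carboxy rather than benzyloxycarbonyl, gives 30.3% and compound 2, which also carries carboxy, gives 38.7%, while compound 3 with the benzyl ester sits lower. On that basis compound 4 is expected to land near compounds 1 and 2, an estimated step of a number 9.8 percentage points higher from compound 3 to compound 4 (within the scatter) in this assay. The estimate for compound 4 is 32%, with a range from 18% to 46%.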

Compound 4, a percentage reported as activity, at one dose (the size of the read-out at that dose, not a potency): 20.4%
Beside the measured number, compound 4's estimate is 11.6 percentage points above it, and the stated range covers the measured number.
By their numbers in this assay, from the lowest: compounds 4, 3, 1 and 2 (each within the scatter of the next, the first and the last beyond it).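

In this assay, hydrogen in place of benzyl on an oxygen next to a carbonyl group gives a number 1.8 percentage points lower from compound 3 to compound 4 (within the scatter), so on the 2-(methylsulfanyl)ethyl side chain the benzyl ester and the free carboxy form cannot be told apart. With carboxy held fixed, the side chain can now be compared directly: 2-(methylsulfanyl)ethyl in place of the sec-butyl of compound 1 gives a number 9.9 percentage points lower from compound 1 to compound 4 (within the scatter), whereas (methylsulfanyl)methyl in place of the hydroxy of compound 2 gives a number 18.3 percentage points lower from compound 2 to compound 4 (beyond the scatter), a modest step and the only one of these three that clears the usual scatter. No measurement in hand gives a reason for any of these steps.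

The compounds shown leave open whether the same swap would also make so little difference on the sec-butyl and hydroxymethyl side chains, since compound 1 and compound 2 appear here only as carboxy compounds. They also leave open how a methyl ester or a primary amide would read in place of the benzyl ester or the carboxy group.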